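Hydroxybenzothiazole anilides: acetyl removal on the aniline nitrogen

The source may report more compounds than this note shows. Statements on the series, on what has been measured and on what is new or still open speak of the compounds shown alone.

Measured compounds:
- compound 1 `CC(=O)Nc1ccc(-c2nc3cccc(O)c3s2)cc1C` gives 48200 nM
- compound 2 `CC(=O)Nc1ccc(-c2nc3c(O)cccc3s2)cc1C` gives 33000 nM
- compound 3 `Cc1cc(-c2nc3cccc(O)c3s2)ccc1N` gives 90800 nM

All three were run in a functional assay on MCF7 cells (Homo sapiens) for cytotoxicity; a lower number here means a stronger inhibitor, a higher number a weaker inhibitor. Compound 1 and compound 2 share the same atoms joined differently; the difference between the two cores is not broken down here. Compound 2 and compound 1 lie within the scatter of each other, so no order between them is claimed. Compound 3 sits furthest from compound 2, beyond the scatter.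

One structural change is seen twice in the series. From compound 1 to compound 3 it reads hydrogen in place of acetyl on a nitrogen on an aromatic ring and gives a 1.9-fold higher number from compound 1 to compound 3 (0.28 log units; within the scatter). The same change, made on the core of compound 2, leads to compound 4 `Cc1cc(-c2nc3c(O)cccc3s2)ccc1N`, which has not yet been measured in this assay; it reads (hydrogen in place of acetyl on a nitrogen on an aromatic ring), and the place is the same in both pairs.

Among the measured compounds shown here, compound 4 is expected to follow the direction seen from compound 1 to compound 3, a step of about a 1.8-fold higher number from compound 2 to compound 4 (0.26 log units; within the scatter), because the only measured instance of this change is a 1.9-fold higher number from compound 1 to compound 3 (0.28 log units; within the scatter). A larger or smaller step cannot be excluded, since a single pair is all that supports the expectation.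

Compound 4 is therefore estimated at 60000 nM in this assay, with a range from 30000 nM to 130000 nM expected.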

Compound 4, half-maximal inhibitory concentration: > 100000 nM
Compound 4 was reported as a limit (the forecaster's own chance of this, stated with the estimate: 15%); at least 1.6-fold (0.22 log units) between middle value and limit.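

In this assay, the acetamido to amino change on the core of compound 2 gives an at least 3.0-fold higher number from compound 2 to compound 4 (0.48 log units; beyond the scatter), a step beyond the scatter, whereas the same change on the core of compound 1 gives a 1.9-fold higher number from compound 1 to compound 3 (0.28 log units; within the scatter), a step within it. The value of compound 4, > 100000 nM, is a limit of the assay and not a number. The series therefore shows that removing the acetyl has a readable cost on one core, but it does not show that the size of the step carries over unchanged or that the step is larger on one core than on the other: the same change on two cores in this assay, a 1.9-fold higher number (0.28 log units; within the scatter) from compound 1 to compound 3 and an at least 3.0-fold higher number (0.48 log units; beyond the scatter) from compound 2 to compound 4; the limit leaves it open whether they differ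

The compounds shown have only acetyl or hydrogen on this nitrogen, which leaves open how a longer acyl chain such as propanoyl, a methyl group on the nitrogen or a methanesulfonyl group would read in this assay. Also open, as far as these compounds go, is whether a methoxy group in place of the hydroxyl would leave the readings on these two cores as they stand.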